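From 2-methoxyphenyl to phenyl: a small step expected

A few compounds are considered here, and "the series" means these few. Any claim that something is new, unique, unknown or untested is made for them only; others in the source may bear on it.

In a functional assay on SGC-7901 cells (Homo sapiens) for inhibition, read by MTT assay, with a stated time of 24 h (on this read-out lower numbers stand for stronger inhibition and higher numbers for weaker inhibition), compound 3 `COc1ccccc1-n1cc(CN2C(=O)C[C@@H]3CC[C@@]2(C)C3(C)C)nn1` gives 280 nM, within the scatter of compound 1 `CC1(C)[C@H]2CC[C@]1(C)N(Cc1cn(-c3cccc(F)c3)nn1)C(=O)C2` at 530 nM and of compound 2 `CC1(C)[C@H]2CC[C@]1(C)N(Cc1cn(-c3ccc(F)cc3)nn1)C(=O)C2` at 500 nM. Compound 4 `CC1(C)[C@H]2CC[C@]1(C)N(Cc1cn(-c3ccccc3)nn1)C(=O)C2` keeps the shared core but has hydrogen in place of methoxy on an aromatic carbon, ortho to a large group: hydrogen in place of methoxy on an aromatic carbon. For the measured compounds named here, no measured pair shows this exact change. The nearest evidence comes from swapping the aryl group on the aromatic nitrogen: a 1.9-fold lower number from compound 1 to compound 3 (0.28 log units; within the scatter), a 1.8-fold lower number from compound 2 to compound 3 (0.25 log units; within the scatter) and a 1.1-fold lower number from compound 1 to compound 2 (0.03 log units; within the scatter). All three stay within the scatter, so no step beyond it is expected in this assay. The expected step is a 1.6-fold higher number from compound 3 to compound 4 (0.21 log units; within the scatter). For compound 4 the estimate is 450 nM, with an expected range of 220 nM to 900 nM.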

Compound 4, half-maximal inhibitory concentration: 240 nM
Estimate against measurement, compound 4: 1.9-fold (0.27 log units) above; the range from low to high includes it.
By their numbers in this assay, from the lowest: compounds 4, 3, 2 and 1 (each within the scatter of the next, the first and the last beyond it).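

Hydrogen in place of methoxy gives a 1.2-fold lower number from compound 3 to compound 4 (0.07 log units; within the scatter) in this assay and so the methoxy is not required for a number at this level. Hydrogen in place of fluoro gives a 2.1-fold lower number from compound 2 to compound 4 (0.32 log units; beyond the scatter) and a 2.2-fold lower number from compound 1 to compound 4 (0.34 log units; beyond the scatter) as the first steps in this short series to pass the scatter, though both are modest. Nothing measured here gives a reason for these steps. As far as these compounds go, what remains open is how an amine or a carboxylic acid on this phenyl ring would read, and whether a longer chain in place of methoxy would hold the number.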